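Swapping the Amine on the Chloro Analogue

The source may hold more compounds than are shown below. What is called first, only, known or untested is meant among the compounds shown, and "the series" means these compounds.

Compound 1 `O=C1C(=O)N(CN2CCCCC2)c2cccc(Br)c21` and compound 2 `CCN(CC)CN1C(=O)C(=O)c2c(Br)cccc21` share a core bearing bromo, while compound 3 `O=C1C(=O)N(CN2CCCCC2)c2cccc(Cl)c21` and compound 4 `CCN(CC)CN1C(=O)C(=O)c2c(Cl)cccc21` carry chloro in its place. In a functional assay on MDA-MB-468 cells (Homo sapiens) for cytotoxicity, read by sulforhodamine B assay, with a stated time of 48 h (a lower number here means a stronger inhibitor of growth, a higher number a weaker inhibitor of growth), compound 1 gives 35300 nM, compound 2 gives 11700 nM and compound 3 gives 82800 nM. The change from compound 1 to compound 2, (diethylamino in place of piperidin-1-yl on a saturated chain carbon bound to an amide-type nitrogen in a ring), brought a 3.0-fold lower number from compound 1 to compound 2 (0.48 log units; beyond the scatter). The two cores differ by chloro in place of bromo on an aromatic carbon, which gave a 2.3-fold higher number from compound 1 to compound 3 (0.37 log units; beyond the scatter). Compound 4 arises from compound 3 by the same change, (diethylamino in place of piperidin-1-yl on a saturated chain carbon bound to an amide-type nitrogen in a ring), at the same place. Because the step of a 3.0-fold lower number from compound 1 to compound 2 (0.48 log units; beyond the scatter) was modest yet beyond the scatter, a similar step is expected from compound 3 to compound 4, estimated as a 3.0-fold lower number from compound 3 to compound 4 (0.48 log units; beyond the scatter). Compound 4 is therefore expected to give 27600 nM, with a likely range from 12000 nM to 60000 nM.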

Compound 4, concentration for 50% growth inhibition: 28300 nM
The estimate for compound 4 lay 1.0-fold (0.01 log units) below the measured number; the measured number falls inside the stated range.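

In this assay, diethylamino in place of piperidin-1-yl gave a 2.9-fold lower number from compound 3 to compound 4 (0.47 log units; beyond the scatter) on the chloro core, and this step matches the one on the bromo core: the same change on two cores in this assay, a 3.0-fold lower number (0.48 log units; beyond the scatter) from compound 1 to compound 2 and a 2.9-fold lower number (0.47 log units; beyond the scatter) from compound 3 to compound 4, 1.0-fold (0.01 log units) apart, within the scatter of two such steps

Chloro in place of bromo, with diethylamino held fixed, gave a 2.4-fold higher number from compound 2 to compound 4 (0.38 log units; beyond the scatter), and this too matches its earlier counterpart: the same change on two cores in this assay, a 2.3-fold higher number (0.37 log units; beyond the scatter) from compound 1 to compound 3 and a 2.4-fold higher number (0.38 log units; beyond the scatter) from compound 2 to compound 4, 1.0-fold (0.01 log units) apart, within the scatter of two such steps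

Across these four compounds, each change therefore carried over from one core to the other at much the same size, but this rests on only two cores in one assay and shows neither that it holds on other cores nor why the numbers move.

From the compounds shown here alone, it remains open whether other amines, such as morpholine or pyrrolidine, would follow the same step. The same question stands for fluoro or methyl on the aromatic carbon that bears bromo or chloro here.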